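Turning Two Stereocentres on the Shared Core

A few compounds are considered here, and "the series" means these few. Any claim that something is new, unique, unknown or untested is made for them only; others in the source may bear on it.

Compound 1 `O=C(O)[C@H]1NC[C@H](O)[C@@H](O)[C@@H]1O` is the higher of the two measured compounds in an assay on isolated protein for inhibition of cytosolic endo-beta-N-acetylglucosaminidase (Homo sapiens), tested at 1000 uM (on this read-out lower numbers stand for less inhibition and higher numbers for more inhibition at the one concentration tested (going by the name of the read-out)), where compound 1 gives 43%. Compound 2 `O=C(O)[C@@H]1NC[C@@H](O)[C@@H](O)[C@@H]1O` has the same atoms and bonds, yet in this assay compound 2 gives only 2.1%; the step of a number 40.9 percentage points lower from compound 1 to compound 2 (beyond the scatter) is large, and the only thing separating the two is the fact that compounds 1 and 2 differ only in the configuration as drawn.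

Compound 3 `O=C(O)[C@@H]1NC[C@H](O)[C@@H](O)[C@H]1O` is the next point to be checked. Relative to compound 1 its change is the two compounds have the same atoms and bonds and differ only in configuration as drawn: 2 of 4 stereo elements differ; a stereocentre at a saturated ring carbon is drawn S in compound 1 and R in compound 3; a stereocentre at a saturated ring carbon is drawn R in compound 1 and S in compound 3. Among the measured compounds shown here, the one measured step that bears on this, the drop from compound 1 to compound 2, shows that redrawing two stereocentres on this core can remove almost all of the inhibition, although compound 3 turns a different pair of centres than compound 2 does, so the size of its effect is not fixed by that single example. A downward step is therefore expected, most likely a large one, and is estimated as a number 31 percentage points lower from compound 1 to compound 3 (beyond the scatter). For compound 3 the inhibition in this assay is estimated at 12%, within a range from 0% to 45%.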

Compound 3, a percentage reported as inhibition, at one concentration (the size of the read-out at that concentration, not a potency): 42%
For compound 3 the middle estimate is 30 percentage points below the measured one; the range from low to high includes it.
By their numbers in this assay, from the lowest: compound 2; then compounds 3 and 1 (each within the scatter of the next).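

Redrawing two stereocentres on the shared core need not cost inhibition in this assay: the result is a number 1 percentage points lower from compound 1 to compound 3 (within the scatter), so compound 1 and compound 3 cannot be told apart here. Among these three compounds, the outcome depends on which pair of stereocentres is turned, and the contrast is clear in the step of a number 39.9 percentage points higher from compound 2 to compound 3 (beyond the scatter), even though both compounds carry the same atoms and bonds. Only configuration separates this last pair, so the spread between them can be traced to it alone: the fact that compounds 2 and 3 differ only in the configuration as drawn

No compound shown turns one stereocentre by itself, so the contribution of each single centre remains unknown, and a reading at one concentration gives no potency. All three compounds carry the carboxylic acid, which leaves open what a methyl ester or an amide in its place would do to the inhibition.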